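Acyl group size in the amide series

The compounds below may be only part of what the source reports. "The series", "measured", "known", "first", "only" and "open" are said of these compounds alone.

In a functional assay (Sus scrofa) with sulfonylurea receptors; K-ATP channels (Homo sapiens) as the target (a higher number here means that more compound is needed for the effect, a lower number that less compound is needed), compound 1 `CCC(=O)Nc1c(C(O)(C(F)(F)F)C(F)(F)F)ccc2ccccc12` gives 8.91 nM, compound 2 `CCCC(=O)Nc1c(C(O)(C(F)(F)F)C(F)(F)F)ccc2ccccc12` gives 708 nM, and compound 3 `O=C(Nc1c(C(O)(C(F)(F)F)C(F)(F)F)ccc2ccccc12)C1CC1` gives 126 nM, the second highest of the three numbers. Compound 4 `O=C(Nc1c(C(O)(C(F)(F)F)C(F)(F)F)ccc2ccccc12)C1CCC1` differs from compound 3 by cyclobutyl in place of cyclopropyl on a carbonyl carbon. Each enlargement of the acyl group seen so far has raised the number in this assay: a 79-fold higher number from compound 1 to compound 2 (1.90 log units; beyond the scatter) and a 14-fold higher number from compound 1 to compound 3 (1.15 log units; beyond the scatter), while a 5.6-fold lower number from compound 2 to compound 3 (0.75 log units; beyond the scatter) places the three-membered ring between ethyl and propyl. Compound 4 carries the larger ring, so a modest rise in this assay is expected, a 4.0-fold higher number from compound 3 to compound 4 (0.60 log units; beyond the scatter). Compound 4 is therefore estimated at 500 nM in this assay, with a range from 150 nM to 1800 nM.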

Compound 4, half-maximal effective concentration: 81.3 nM
Compound 4: middle estimate off by 6.2-fold (0.79 log units), on the high side; the whole stated range lies above it.
By their numbers in this assay, from the lowest: compound 1; then compounds 4 and 3 (each within the scatter of the next); then compound 2.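

In this assay, cyclobutyl in place of cyclopropyl on a carbonyl carbon gives no readable difference (a 1.5-fold lower number from compound 3 to compound 4 (0.19 log units; within the scatter)), so the ring enlargement does not repeat the rise seen on going from ethyl to propyl. Cyclobutyl also stays clearly apart from both open chains, with propyl on one side (an 8.7-fold lower number from compound 2 to compound 4 (0.94 log units; beyond the scatter)) and ethyl on the other (a 9.1-fold higher number from compound 1 to compound 4 (0.96 log units; beyond the scatter)). The compounds shown offer no measurement that accounts for this.

From the compounds shown here alone, whether cyclopentyl or cyclohexyl on the same carbonyl carbon would hold the level of the two smaller rings remains open. So does the reading for a branched isopropyl group or a smaller acetyl group.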